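Growing the amide substituent: does the half-life move?

The source may hold more compounds than are shown below. What is called first, only, known or untested is meant among the compounds shown, and "the series" means these compounds.

In an ADME assay on microsomes from liver (Mus musculus, strain CD-1) for metabolic stability, read by LC-MS, tested at 2 uM (on this read-out lower numbers stand for a shorter-lived compound and higher numbers for a longer-lived compound), three compounds have been measured. Compound 1 `CNS(=O)(=O)c1ccccc1Nc1cc(-c2ccc3ccn(C)c3c2)c2nccnc2c1` gives 0.2 h, and compound 2 `Cn1ccc2ccc(-c3cc(Nc4ccccc4S(=O)(=O)N4CCOCC4)cc4nccnc34)cc21` gives 0.367 h. Compound 3 `CNC(=O)c1ccncc1Nc1cc(-c2ccc3ccn(C)c3c2)c2nccnc2c1` gives 0.45 h. Its gap to compound 1 lies beyond the scatter, while its gap to compound 2 stays within the scatter.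

Compound 4 `CC(=O)N1CC(CNC(=O)c2ccncc2Nc2cc(-c3ccc4ccn(C)c4c3)c3nccnc3c2)C1` differs from compound 3 by the change (1-acetylazetidin-3-yl in place of hydrogen on a saturated chain carbon bound to an amide-type nitrogen). Read one bond further out, methylcarbamoyl becomes ((1-acetylazetidin-3-yl)methyl)carbamoyl.

Within the data shown here, no measured step touches this amide-type nitrogen directly. Among the measured compounds shown here, the only single-point step available is a 1.8-fold higher number from compound 1 to compound 2 (0.26 log units; within the scatter), in which a larger group replaced a smaller one on a sulfonyl sulfur, and that step stayed within the scatter. Compound 3 and compound 4 share every other feature. On this basis the step of a 1.1-fold higher number from compound 3 to compound 4 (0.05 log units; within the scatter) is expected to remain within the scatter, with no clear direction. Compound 4 is therefore expected to give about 0.5 h, with a range from 0.25 h to 1 h.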

Compound 4, half-life: > 1 h
Compound 4: only a limit was reported; the forecaster's own chance of this, stated with the estimate: 5%; middle value at least 2.0-fold (0.30 log units) away from the limit.
By their numbers in this assay, from the lowest: compounds 1, 2 and 3 (each within the scatter of the next, the first and the last beyond it). At a limit, above all of these: compound 4.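

In this assay, setting 1-acetylazetidin-3-yl in place of hydrogen on a saturated chain carbon bound to an amide-type nitrogen gives an at least 2.2-fold higher number from compound 3 to compound 4 (0.34 log units; beyond the scatter). Among these compounds, this is the first single-place change here to go beyond the scatter; the only earlier one, a 1.8-fold higher number from compound 1 to compound 2 (0.26 log units; within the scatter), sat on a sulfonyl sulfur and stayed within it. Compound 4 gives > 1 h, which is a limit of the assay and not a number, so its true half-life and the full size of the step remain unfixed: the limit of > 1 h in this assay, at which 1 of the 4 values shown sits.

The compounds shown do not separate the part played by the acetyl group from that of the four-membered ring. A plain longer chain, or the same azetidine ring with a free amine in place of the acetylated nitrogen, would test which part matters.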